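This account rests on a few compounds, and the source may have more. Where it says the series, first, only, none or still open, it means among the compounds named here.

Compound 2, `COc1ccc(-c2cs/c(=N/NC(=O)CSc3ncccn3)n2-c2ccccc2)cc1`, belongs to a small set of close relatives examined for their effect on the growth of rat glioma cells. In a functional assay on C6 cells (Rattus norvegicus) for cytotoxicity, read by MTT assay, with a stated time of 24 h, tested at 25 ug/mL (on this read-out lower numbers stand for a stronger effect and higher numbers for a weaker effect at the one concentration tested), compound 2 gives 74%. The only other measured relative is compound 1, `O=C(CSc1ncccn1)N/N=c1/scc(-c2ccc(Br)cc2)n1-c1ccccc1`, which in this assay gives 72.3%; the two numbers lie within the scatter of each other, as the step of a number 1.7 percentage points higher from compound 1 to compound 2 (within the scatter) shows.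

Compound 3, `O=C(CSc1ncccn1)N/N=c1/scc(-c2ccc(F)cc2)n1-c1ccccc1`, has not yet been measured. It differs from compound 2 by fluoro in place of methoxy on an aromatic carbon. Among the compounds with values here, the one measured step, a number 1.7 percentage points higher from compound 1 to compound 2 (within the scatter), also exchanged a group on that same aromatic carbon and left the read-out essentially unchanged. Within the data shown here, no measured step involves a fluoro group, so the expectation rests on that single comparison alone. Compound 3 is therefore expected to show a step of a number 1 percentage points lower from compound 2 to compound 3 (within the scatter), nothing beyond the scatter. For compound 3 the estimated value in this assay is 73%, with a range from 61% to 85%.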

Compound 3, a percentage reported as activity, at one concentration (the size of the read-out at that concentration, not a potency): 63.9%
The estimate for compound 3 lay 9.1 percentage points above the measured number, and the stated range covers the measured number.
By their numbers in this assay, from the lowest: compounds 3, 1 and 2 (each within the scatter of the next, the first and the last beyond it).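

Within the data shown here, this aromatic carbon, para to a large group, is not indifferent to what it carries: in this assay the exchange of methoxy for fluoro gives a number 10.1 percentage points lower from compound 2 to compound 3 (beyond the scatter) and is the only step here that leaves the scatter, pointing to a stronger effect for the 4-fluorophenyl compound than for the 4-methoxyphenyl one. Exchanging bromo for fluoro at the same carbon gives a number 8.4 percentage points lower from compound 1 to compound 3 (within the scatter) and so does not separate those two compounds, which means that only the pairing of fluoro with methoxy stands apart. Nothing available explains why these groups differ.

From the compounds shown here alone, whether an amine, a hydroxyl group, a nitrile or a longer chain such as ethoxy at this carbon would lower the number further remains open. So does whether the modest gap between fluoro and methoxy would hold at other concentrations.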